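The source may hold more compounds than are shown below. What is called first, only, known or untested is meant among the compounds shown, and "the series" means these compounds.

Working notes on the series. In a functional assay on CCRF-CEM cells (Homo sapiens) for cytotoxicity, read by XTT assay, with a stated time of 3 days (a lower number here means a stronger inhibitor, a higher number a weaker inhibitor), compound 1 `OC[C@H]1O[C@@H](n2cc(F)c3c(-c4ccco4)ncnc32)[C@H](O)[C@@H]1O` gives 1400 nM. Compound 2 `OC[C@H]1O[C@@H](n2cc(F)c3c(-c4cccs4)ncnc32)[C@H](O)[C@@H]1O` carries thiophen-2-yl in place of furan-2-yl on an aromatic carbon and in this assay compound 2 gives 270 nM; the step is a 5.2-fold lower number from compound 1 to compound 2 (0.71 log units; beyond the scatter). Compound 3 `OC[C@H]1O[C@@H](n2cc(Cl)c3c(-c4ccco4)ncnc32)[C@H](O)[C@@H]1O` differs from compound 1 by chloro in place of fluoro on an aromatic carbon, and in this assay compound 3 gives 3800 nM, the step being a 2.7-fold higher number from compound 1 to compound 3 (0.43 log units; beyond the scatter); no step is given between compound 2 and compound 3, their two values simply stand apart as shown.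

Compound 4 `OC[C@H]1O[C@@H](n2cc(Cl)c3c(-c4cccs4)ncnc32)[C@H](O)[C@@H]1O` is not yet measured. Against compound 3 it carries thiophen-2-yl in place of furan-2-yl on an aromatic carbon, the same change as that made from compound 1 to compound 2, with the same surroundings word for word, occurring twice among the compounds here. Within the data shown here, the only precedent is the single step of a 5.2-fold lower number from compound 1 to compound 2 (0.71 log units; beyond the scatter) from compound 1 to compound 2, so the expectation for compound 4 rests on one pair and is held loosely. The step from compound 3 to compound 4 is expected to be a 5.1-fold lower number from compound 3 to compound 4 (0.70 log units; beyond the scatter), of about the size seen in compound 2 because of a 5.2-fold lower number from compound 1 to compound 2 (0.71 log units; beyond the scatter). On that basis compound 4 is estimated at 750 nM in this assay, with a range from 350 nM to 1600 nM.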

Compound 4, half-maximal inhibitory concentration: 2700 nM
The estimate for compound 4 lay 3.6-fold (0.56 log units) below the measured number; the measured number lies above the stated range.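

In this assay, the replacement of furan-2-yl by thiophen-2-yl does not carry over from the core of compound 1 to the core of compound 3, where the step shrinks to a 1.4-fold lower number from compound 3 to compound 4 (0.15 log units; within the scatter), and the two steps differ: the same change on two cores in this assay, a 5.2-fold lower number (0.71 log units; beyond the scatter) from compound 1 to compound 2 and a 1.4-fold lower number (0.15 log units; within the scatter) from compound 3 to compound 4, 3.7-fold (0.57 log units) apart, beyond the scatter of two such steps

Read the other way, chloro in place of fluoro gives a larger step with thiophen-2-yl, at a 10-fold higher number from compound 2 to compound 4 (1.00 log units; beyond the scatter), than with furan-2-yl: the same change on two cores in this assay, a 2.7-fold higher number (0.43 log units; beyond the scatter) from compound 1 to compound 3 and a 10-fold higher number (1.00 log units; beyond the scatter) from compound 2 to compound 4, 3.7-fold (0.57 log units) apart, beyond the scatter of two such steps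

Both comparisons rest on the same four compounds, so they record one departure from simple addition of the two changes: they show that the effect of each change depends on the other here, but not why, nor whether this holds beyond these compounds.

The compounds shown leave open how the same replacement behaves with a group such as bromo or methyl in place of the fluoro or chloro. Also open, going by these compounds, is whether an amine or a phenyl in place of the thiophen-2-yl would show the same dependence.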